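The source may report more compounds than this note shows. Statements on the series, on what has been measured and on what is new or still open speak of the compounds shown alone.

The measured compounds, all read in a functional assay on NCI-H460 cells (Homo sapiens) for cytotoxicity, read by MTT assay, with a stated time of 72 h; a lower number here means a stronger inhibitor, a higher number a weaker inhibitor:

Compound 1, `COc1cc2c(Oc3ccc(NC(=O)c4cc(-c5cccc(Cl)c5)nc5ccccc45)cc3F)ccnc2cc1OCCCN1CCC(C)CC1`, gives 65 nM.
Compound 2, `COc1cc2c(Oc3ccc(NC(=O)c4cc(-c5ccccc5)nc5ccccc45)cc3F)ccnc2cc1OCCCN1CCC(C)CC1`, gives 68 nM.
Compound 3, `COc1ccc(-c2cc(C(=O)Nc3ccc(Oc4ccnc5cc(OCCCN6CCC(C)CC6)c(OC)cc45)c(F)c3)c3ccccc3n2)cc1`, gives 110 nM.

Compound 3 carries the highest of the three numbers, but it is not set apart from the others: the change from compound 1 to compound 3 reads a 1.7-fold higher number from compound 1 to compound 3 (0.23 log units; within the scatter), and from compound 2 to compound 3 a 1.6-fold higher number from compound 2 to compound 3 (0.21 log units; within the scatter), both within the scatter, as is a 1.0-fold higher number from compound 1 to compound 2 (0.02 log units; within the scatter).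

Compound 4, `COc1cc2c(Oc3ccc(NC(=O)c4cc(-c5ccc(C)cc5)nc5ccccc45)cc3F)ccnc2cc1OCCCN1CCC(C)CC1`, differs from compound 3 by methyl in place of methoxy on an aromatic carbon. Going by the values given here, the step that bears on it most directly is the one from compound 2 to compound 3, in which a methoxy entered on the same ring without moving the number beyond the scatter; the exchanges on this ring between compound 1 and compound 2 and between compound 1 and compound 3 were likewise flat. Compound 4 is therefore expected to stay within the scatter of compound 3, a 1.2-fold lower number from compound 3 to compound 4 (0.09 log units; within the scatter), with no direction beyond that. The estimate for compound 4 is 90 nM, between 40 nM and 200 nM.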

Compound 4, half-maximal inhibitory concentration: 880 nM
Compound 4: the middle estimate sits 9.8-fold (0.99 log units) below what was measured, and the stated range ends below it.
By their numbers in this assay, from the lowest: compounds 1, 2 and 3 (each within the scatter of the next); then compound 4.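

Going by these compounds alone, at this place on the aromatic ring, para to a large group, the exchanges among the earlier compounds stayed within the scatter in this assay, so the position had looked indifferent to what it carries. Compound 4 shows that it is not: the change to 4-methylphenyl gives an 8.0-fold higher number from compound 3 to compound 4 (0.90 log units; beyond the scatter) and, against the other two compounds, a 13-fold higher number from compound 2 to compound 4 (1.11 log units; beyond the scatter) and a 14-fold higher number from compound 1 to compound 4 (1.13 log units; beyond the scatter). The result also does not follow group size in any simple order, since methyl is smaller than methoxy and larger than hydrogen, yet only the methyl compound stands apart.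

Nothing available explains why methyl separates from hydrogen and methoxy here. From the compounds shown here alone, it remains open whether an ethyl group, a hydroxyl, an amine or a carboxylic acid at this place would stay with compounds 2 and 3 or fall with compound 4.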